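Isopentyl on the ring amine nitrogen

This account rests on a few compounds, and the source may have more. Where it says the series, first, only, none or still open, it means among the compounds named here.

Measured so far:
compound 1 `CC(C)N1CCN(C(=O)CCc2c(-c3ccc(Cl)cc3)n(C)c3ccc(Cl)cc23)CC1` gives 13 nM in an assay on CHO cells with Substance-P receptor (Homo sapiens) as the target; a higher number here means a weaker inhibitor, a lower number a stronger inhibitor.
compound 2 `Cn1c(-c2ccc(Cl)cc2)c(CCC(=O)N2CCN(C3CCCCC3)CC2)c2cc(Cl)ccc21` gives 0.35 nM in this assay.

Within the data shown here, compound 2 stands at the lowest of the two numbers; the only step, a 37-fold lower number from compound 1 to compound 2 (1.57 log units; beyond the scatter), is large. Compound 3 `CC(C)CCN1CCN(C(=O)CCc2c(-c3ccc(Cl)cc3)n(C)c3ccc(Cl)cc23)CC1` differs from compound 2 by isopentyl in place of cyclohexyl on an amine nitrogen in a ring. That single step bears on this change and shows the group on the ring amine nitrogen matters strongly; isopentyl has no ring, so a rise toward compound 1 is expected, but smaller than that measured step. Compound 3 is estimated at 3 nM in this assay, range 0.7 nM to 15 nM. The expected step is an 8.6-fold higher number from compound 2 to compound 3 (0.93 log units; beyond the scatter).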

Compound 3, half-maximal inhibitory concentration: 0.34 nM
Compound 3: middle estimate off by 8.8-fold (0.95 log units), on the high side; the whole stated range lies above it.
By their numbers in this assay, from the lowest: compounds 3 and 2 (each within the scatter of the next); then compound 1.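

In this assay, the ring of cyclohexyl is not needed on this ring amine nitrogen: open-chain isopentyl gives a number within the scatter of it (a 1.0-fold lower number from compound 2 to compound 3 (0.01 log units; within the scatter)). Isopentyl and isopropyl both lack a ring, yet they are clearly separated (a 38-fold lower number from compound 1 to compound 3 (1.58 log units; beyond the scatter)), so the presence of a ring does not account for the gap to compound 1. No supporting data bear on the reason for this result.

Still open, from the compounds shown here alone, is whether a longer chain, a benzyl group or a chain carrying a hydroxyl group would hold the number at this level.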